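Tolyl Triazole Sulfonamides: Methyl Position and Cytotoxicity

The compounds below may be only part of what the source reports. "The series", "measured", "known", "first", "only" and "open" are said of these compounds alone.

Compound 1 `Cc1ccccc1-n1cc(-c2cccc(NS(=O)(=O)c3c[nH]c(=O)[nH]c3=O)c2)nn1` and compound 2 `Cc1cccc(-n2cc(-c3cccc(NS(=O)(=O)c4c[nH]c(=O)[nH]c4=O)c3)nn2)c1` share one core; compound 3 `Cc1ccccc1-n1cc(-c2ccc(NS(=O)(=O)c3c[nH]c(=O)[nH]c3=O)cc2)nn1` and compound 4 `Cc1cccc(-n2cc(-c3ccc(NS(=O)(=O)c4c[nH]c(=O)[nH]c4=O)cc3)nn2)c1` share another, and the difference between the two cores is not broken down here. In an ADME assay on GES1 cells (Homo sapiens) for cytotoxicity, read by MTT assay, with a stated time of 24 h (a higher number here means that more compound is tolerated, a lower number that less compound is tolerated), compound 1 gives 21500 nM, and compound 2 gives 18500 nM. The change between them, (3-methylphenyl in place of 2-methylphenyl on an aromatic nitrogen), made a 1.2-fold lower number from compound 1 to compound 2 (0.07 log units; within the scatter). For compound 3 this assay records "not toxic" (no number reported), with no number attached. Compound 4 carries the same change on its own core, (3-methylphenyl in place of 2-methylphenyl on an aromatic nitrogen). Among the compounds with values here, the only guide to its size is the earlier step, which lay within the scatter, so no shift in tolerated concentration is expected; a qualitative outcome without a number is at least as likely as a value. Compound 4 is expected to lie near 40000 nM, between 15000 nM and 120000 nM.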

Compound 4, half-maximal cytotoxic concentration: 28300 nM
For compound 4 the middle estimate is 1.4-fold (0.15 log units) above the measured one; measured number inside the range.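

Within the data shown here, compound 3 carries only a "not toxic" record in this assay, so no step to compound 4 can be read. On these data alone, whether the change from 2-methylphenyl to 3-methylphenyl behaves alike on both cores stays open. No measured evidence bears on this result.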